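A few compounds are considered here, and "the series" means these few. Any claim that something is new, unique, unknown or untested is made for them only; others in the source may bear on it.

Compound 1 `CCOC(=O)c1c(-c2ccccc2)[nH]c2cc(OC)ccc2c1=O` gives > 21500 nM in an ADME assay on BJ cells (Homo sapiens) for cytotoxicity, read by luminescence, with a stated time of 72 h; a lower number here means that less compound is needed, a higher number that more compound is needed for the effect; this value is a limit of the assay, not a number.
Compound 2 `CCOC(=O)c1c(-c2cccc(C)c2)[nH]c2cc(OC)ccc2c1=O` gives > 21500 nM in this assay, again a limit.
Compound 3 `C=Cc1cccc(-c2[nH]c3cc(OC)ccc3c(=O)c2C(=O)OCC)c1` gives > 21500 nM in this assay, again a limit.

On the numbers shown, compound 1 stands at a limit of the assay, so its true value is unknown beyond that point. The step to compound 4 `CCOC(=O)c1c(-c2cccc(OCC(C)C)c2)[nH]c2cc(OC)ccc2c1=O` is isobutoxy in place of hydrogen on an aromatic carbon, on an aromatic carbon of a six-membered aromatic ring of carbon only, meta to a large group.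

Three measured steps change the same ring in a similar way: a step that the two limits leave unreadable from compound 1 to compound 2, a step that the two limits leave unreadable from compound 1 to compound 3 and a step that the two limits leave unreadable from compound 2 to compound 3. None of them can be read, because of the limit of > 21500 nM in this assay, at which 3 of the 3 values shown sit. So there is no measured step from which a size or direction can be taken for the change to compound 4; the only available pattern is that every group tried on this ring left the value at the limit.

The expectation for compound 4 is therefore that it too stays at the limit, with a step that the limit leaves unreadable from compound 1 to compound 4 as the estimated step. Compound 4 is estimated at 30000 nM, with a range from 12000 nM to 100000 nM.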

Compound 4, half-maximal effective concentration: > 21500 nM
Compound 4 gave a limit, no number; the forecaster's own chance of this, stated with the estimate: 85%; the middle value is on the limit's open side.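

Compound 4 sits at a limit, as do compound 1, compound 2 and compound 3, so no step among these four compounds can be read: (the limit of > 21500 nM in this assay, at which 4 of the 4 values shown sit). Still open, on these data alone, is where their true values lie, and whether any of these groups changes the value at all.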